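Bromo for a benzylic alcohol on the phenyl of compound 2

The compounds below may be only part of what the source reports. "The series", "measured", "known", "first", "only" and "open" are said of these compounds alone.

Three compounds of the series share one core and differ only in the group on the phenyl ring. Compound 1 `CCCCCCCCCCCCOc1cccc(N2C(N)=NC(N)=NC2(C)C)c1` carries a long alkoxy chain and gives 6.41 in a functional assay on L5178Y cells (Mus musculus) for inhibition; a lower number here means a less potent compound, a higher number a more potent compound, by a factor of ten per unit of this negative logarithm. Compound 2 `CC1(C)N=C(N)N=C(N)N1c1cccc(C(O)c2ccccc2)c1` carries a hydroxy(phenyl)methyl group and in this assay compound 2 gives 6.41. Compound 3 `CC1(C)N=C(N)N=C(N)N1c1cccc(OCCOc2ccccc2)c1` carries a phenoxyethoxy group and in this assay compound 3 gives 7.34.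

On these numbers compound 2 stands level with compound 1 at the digits given, the two together being the lowest of the three, and the value of compound 3 lies clearly above both, beyond the usual scatter.

Compound 4 `CC1(C)N=C(N)N=C(N)N1c1cccc(Br)c1` has not yet been measured. The change from compound 2 to compound 4 is bromo in place of hydroxy(phenyl)methyl on an aromatic carbon. Among the compounds with values here, the group that leaves is large and the one that enters is small; no measured pair shows such a step. The only trend visible is that the largest substituent, in compound 3, gives the highest number, while the two other large groups give the same lower number.

For compound 4 a modest loss is expected, with the step from compound 2 estimated as a number 0.41 log units lower from compound 2 to compound 4 (beyond the scatter). Compound 4 is therefore expected to give about 6 in this assay, within the range 5.2 to 6.8.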

Compound 4, logarithm of the reciprocal of the active concentration, log(1/C): 8.42
Compound 4: the middle estimate sits 2.42 log units below what was measured; measured number above the stated range.
By their numbers in this assay, from the lowest: compounds 1 and 2 (each within the scatter of the next); then compound 3; then compound 4.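

The step in this assay reads a number 2.01 log units higher from compound 2 to compound 4 (beyond the scatter), on replacing hydroxy(phenyl)methyl with bromo on an aromatic carbon. This position therefore does not need a large group, its aromatic ring or its hydrogen-bond donor and acceptor for a high number: the single bromine atom suffices, which compounds 1 to 3, all with large groups here, could not show. Nothing measured in the compounds shown bears on why this change moves the number so far.

This one step leaves open whether the number follows the bromine itself or simply the departure of the hydroxy(phenyl)methyl group; chloro, methyl or plain hydrogen on the same carbon would separate the two readings. Also open, on these data alone, is whether an amine, a carboxylic acid or a methoxy group at this place would hold the level of compound 4 at 8.42 in this assay.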